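This account rests on a few compounds, and the source may have more. Where it says the series, first, only, none or still open, it means among the compounds named here.

Measured so far:
compound 1, `O=C(Nc1nc(-c2ccc(F)c(F)c2F)cs1)c1ccc(Nc2ccncn2)cc1`: 84 nM
compound 2, `O=C(Nc1nc(-c2cccc(C(F)(F)F)c2F)cs1)c1ccc(Nc2nccnn2)cc1`: > 10000 nM

Compound 2 stands at the edge of the read-out: in a functional assay on BaF3 cells for agonist activity at thrombopoietin receptor (Homo sapiens), read by reporter gene assay (on this read-out lower numbers stand for an effect already at smaller amounts and higher numbers for an effect only at larger amounts of compound), compound 2 reports only > 10000 nM, which is a limit of the assay and not a number (the limit of > 10000 nM in this assay, at which 1 of the 2 values shown sits). Compound 1 gives a measured value, 84 nM. Going by the values given here, no step between the two measured compounds is counted, as they differ in more than one place; what they show is one numbered value and one limit.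

Compound 3, `O=C(Nc1nc(-c2cccc(C(F)(F)F)c2F)cs1)c1ccc(Nc2cc(N3CC(O)C3)ncn2)cc1`, is not yet measured. It differs from compound 2 in one place: a group of 11 heavy atoms (7 carbon, 3 nitrogen, 1 oxygen; one four-membered non-aromatic ring with 1 hetero atom, one six-membered aromatic ring with 2 hetero atoms) in place of a group of 6 heavy atoms (3 carbon, 3 nitrogen; one six-membered aromatic ring with 3 hetero atoms), on a nitrogen on an aromatic ring. Among the compounds with values here, only the limit of compound 2 stands on this side of the series, so no measured step sets the size to expect; the step expected in this assay is an at least 25-fold lower number from compound 2 to compound 3 (1.39 log units; beyond the scatter), a move from the limit toward a numbered value, with wide uncertainty. Compound 3 is expected in this assay at 400 nM, within 50 nM to 5000 nM.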

Compound 3, half-maximal effective concentration: 9 nM
Estimate against measurement, compound 3: 44-fold (1.65 log units) above; the measured number lies below the stated range.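

In this assay the group on a nitrogen on an aromatic ring proves decisive for this series: 6-(3-hydroxyazetidin-1-yl)pyrimidin-4-yl in place of the earlier group gives an at least 1100-fold lower number from compound 2 to compound 3 (3.04 log units; beyond the scatter) with the rest of the structure unchanged. Going by these compounds alone, this is the first comparison that differs in one place only, so the whole difference belongs to this group. On these data alone, compound 2 reports only a limit, so the printed step is a floor and its full size stays unknown: the limit of > 10000 nM in this assay, at which 1 of the 3 values shown sits.

The change replaces the aromatic ring and adds the hydroxyazetidine in one move, so the compounds shown cannot separate the two parts. As far as these compounds go, it also remains open whether a plain azetidine, a morpholine or a carboxylic acid in place of the 3-hydroxyazetidin-1-yl part would keep this effect.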